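The source may hold more compounds than are shown below. What is called first, only, known or untested is meant among the compounds shown, and "the series" means these compounds.

For the measured compounds named here, compound 2 `COc1ccc(C2=Nn3c(nnc3C(C)c3ccc4cc(OC)ccc4c3)SC2)cc1` gives 6500 nM in a functional assay on HCT-116 cells (Homo sapiens) for inhibition, read by sulforhodamine B assay, with a stated time of 72 h (a higher number here means a weaker inhibitor, a lower number a stronger inhibitor), and stands lowest of the two numbers so far; compound 1 `COc1ccc2cc(C(C)c3nnc4n3N=C(c3ccc(Cl)cc3Cl)CS4)ccc2c1` gives 14000 nM, and the step of a 2.2-fold lower number from compound 1 to compound 2 (0.33 log units; beyond the scatter) is the only one measured. Compound 3 `COc1ccc2cc(C(C)c3nnc4n3N=C(c3ccc(C)cc3)CS4)ccc2c1` differs from compound 2 by methyl in place of methoxy on an aromatic carbon. Going by the values given here, no measured step touches this change: the one step known alters the whole aryl group, not a single substituent on it, and is modest in size. Compound 3 is therefore expected to stay near compound 2, with a step of a 1.1-fold higher number from compound 2 to compound 3 (0.03 log units; within the scatter) not beyond the scatter, estimated at 7000 nM within 3000 nM to 16000 nM.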

Compound 3, half-maximal inhibitory concentration: 10200 nM
Compound 3: the middle estimate sits 1.5-fold (0.16 log units) below what was measured; the range from low to high includes it.
By their numbers in this assay, from the lowest: compounds 2, 3 and 1 (each within the scatter of the next, the first and the last beyond it).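

Methyl in place of methoxy gives a 1.6-fold higher number from compound 2 to compound 3 (0.20 log units; within the scatter) in this assay and so leaves this change at the aromatic carbon unresolved. Going from 2,4-dichlorophenyl to 4-methylphenyl gives a 1.4-fold lower number from compound 1 to compound 3 (0.14 log units; within the scatter) and is likewise unresolved, while only 4-methoxyphenyl stands beyond the scatter from 2,4-dichlorophenyl. Nothing available explains these numbers.

From the compounds shown here alone, whether an amine or a carboxylic acid on this aromatic carbon would move the number beyond the scatter remains open. So does the effect of a plain hydrogen there.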